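Pyrimidin-5-yl in place of 5-methoxypyrazin-2-yl

The compounds below may be only part of what the source reports. "The series", "measured", "known", "first", "only" and "open" are said of these compounds alone.

In an ADME assay on microsomes from liver (Rattus norvegicus) for metabolic stability (on this read-out higher numbers stand for a longer-lived compound and lower numbers for a shorter-lived compound), compound 3 `COc1cc(OCc2cccc(-c3cnc(OC)cn3)c2)c2cc(-c3cn4nc(OC)sc4n3)oc2c1` gives 1.62 h. Compound 2 `COc1cc(OCc2cccc(-c3ccc(C#N)cn3)c2)c2cc(-c3cn4nc(OC)sc4n3)oc2c1` gives 0.833 h, and a 1.9-fold higher number from compound 2 to compound 3 (0.29 log units; within the scatter) stays within the scatter. Compound 1 `COc1cc(OCc2cccc(-c3ccc(C(F)(F)F)cn3)c2)c2cc(-c3cn4nc(OC)sc4n3)oc2c1` gives > 2 h, which is a limit of the assay and not a number. Two further steps start from that limit: an at least 2.4-fold lower number from compound 1 to compound 2 (0.38 log units; beyond the scatter), and an at least 1.2-fold lower number from compound 1 to compound 3 (0.09 log units; that floor lies within the scatter).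

Compound 4 `COc1cc(OCc2cccc(-c3cncnc3)c2)c2cc(-c3cn4nc(OC)sc4n3)oc2c1` differs from compound 3 in one place: pyrimidin-5-yl in place of 5-methoxypyrazin-2-yl on an aromatic carbon. The new group sits on an aromatic carbon of a six-membered aromatic ring of carbon only, meta to a large group. For the measured compounds named here, no measured compound carries pyrimidin-5-yl, so the closest guides are the two steps that exchange the group at this same place, an at least 1.2-fold lower number from compound 1 to compound 3 (0.09 log units; that floor lies within the scatter) and a 1.9-fold higher number from compound 2 to compound 3 (0.29 log units; within the scatter). Neither shows a step clearly beyond the scatter, so only a small move is expected, leaning towards a lower number. The expected step is a 1.5-fold lower number from compound 3 to compound 4 (0.17 log units; within the scatter). Compound 4 is estimated at 1.1 h, with an expected range of 0.55 h to 2 h.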

Compound 4, half-life: 0.117 h
Beside the measured number, compound 4's estimate is 9.4-fold (0.97 log units) above it; the measured number lies below the stated range.
By their numbers in this assay, from the lowest: compound 4; then compounds 2 and 3 (each within the scatter of the next). At a limit, above all of these: compound 1.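

In this assay, compounds 2 and 3 had suggested that the group at this place matters little, but compound 4 shows that it can change the half-life far more than that. Pyrimidin-5-yl separates compound 4 clearly from both, with a 14-fold lower number from compound 3 to compound 4 (1.14 log units; beyond the scatter) and a 7.1-fold lower number from compound 2 to compound 4 (0.85 log units; beyond the scatter). Compound 1 stands at a limit of the assay, so an at least 17-fold lower number from compound 1 to compound 4 (1.23 log units; beyond the scatter) gives only a floor for that step: the limit of > 2 h in this assay, at which 1 of the 4 values shown sits.

The compounds shown do not separate the loss of a substituent from the change of ring, since pyrimidin-5-yl differs from all three earlier groups in both respects. A 2-methoxypyrimidin-5-yl or an unsubstituted pyrazin-2-yl group would bear on that question, and the cause of the fall remains unknown.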